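Removing the side arm of compound 2

This account rests on a few compounds, and the source may have more. Where it says the series, first, only, none or still open, it means among the compounds named here.

Among the measured compounds shown here, compound 2 `O=C1O[C@H]([C@@H](O)Cn2cc(CNS(=O)(=O)c3ccc(F)cc3)nn2)C(OCc2ccccc2)=C1OCc1ccccc1` is the only member with a numeric reading: in a functional assay on HepG2 cells (Homo sapiens) for antiproliferative activity, read by MTT assay, with a stated time of 72 h (on this read-out higher numbers stand for weaker inhibition and lower numbers for stronger inhibition), compound 2 gives 18300 nM. Compound 1 `Cc1ccc(-c2cn(C/C=C3\OC(=O)C(OCc4ccccc4)=C3OCc3ccccc3)nn2)cc1` returns only a limit, > 100000 nM, in this assay. Compound 3 `CC(C)(C)OC(=O)N1CCN(C(=S)SCc2cn(C[C@H](O)[C@H]3OC(=O)C(OCc4ccccc4)=C3OCc3ccccc3)nn2)CC1` likewise reaches only a limit, > 100000 nM, in this assay. the limit of > 100000 nM in this assay, at which 2 of the 3 values shown sit, is where most of the set sits. Compound 4 `O=C1O[C@H]([C@@H](O)Cn2ccnn2)C(OCc2ccccc2)=C1OCc1ccccc1` strips the arm off: hydrogen in place of (((4-fluorophenyl)sulfonyl)amino)methyl on an aromatic carbon. For the measured compounds named here, no measured pair shows a change of this kind, so the size of the step is open; the expectation is a loss of inhibition in this assay beyond the scatter, with a fair chance that compound 4 reports only a limit. The expected step from compound 2 to compound 4 is a 3.3-fold higher number from compound 2 to compound 4 (0.52 log units; beyond the scatter). Compound 4 is estimated at 60000 nM, between 15000 nM and 250000 nM.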

Compound 4, half-maximal inhibitory concentration: > 100000 nM
Compound 4: only a limit was reported; the forecaster's own chance of this, stated with the estimate: 55%; middle value at least 1.6-fold (0.22 log units) away from the limit.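

On the shared core, hydrogen in place of the (((4-fluorophenyl)sulfonyl)amino)methyl arm on the aromatic carbon gives, in this assay, an at least 5.4-fold higher number from compound 2 to compound 4 (0.73 log units; beyond the scatter). Measurable inhibition within this pair therefore depends on the arm, while the full size of the step cannot be read, since compound 4 reports only a limit. Compound 4 joins most of the set: the limit of > 100000 nM in this assay, at which 3 of the 4 values shown sit.

Going by these compounds, it remains open which part of the arm matters, and whether a plain aminomethyl group or a carboxylic acid on this carbon would keep the reading. Steps involving compound 1 or compound 3 cannot be read, since each differs from the others in more than one place.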